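The source may hold more compounds than are shown below. What is called first, only, known or untested is meant among the compounds shown, and "the series" means these compounds.

Measured so far, all as limits:
- Compound 1 `Cn1c(-c2ccccc2F)nnc1S(C)(=O)=O`: > 100 mg/kg
- Compound 2 `CCSc1nnc(-c2ccccc2F)n1C`: > 200 mg/kg
- Compound 3 `CC[S+]([O-])c1nnc(-c2ccccc2F)n1C`: > 200 mg/kg

The read-out is a functional assay on the whole organism for antagonist activity, with Mus musculus as the target; a higher number here means that more compound is needed for the effect, a lower number that less compound is needed. Among the compounds with values here, compound 3 stands only at a limit, > 200 mg/kg, and no compound has yet given a number.

The next step leads to compound 4 `CCS(=O)(=O)c1nnc(-c2ccccc2F)n1C`. The change is a group of 5 heavy atoms (2 carbon, 2 oxygen, 1 sulfur; no ring) in place of a group of 4 heavy atoms (2 carbon, 1 oxygen, 1 sulfur; no ring), on an aromatic carbon: ethylsulfonyl enters on an aromatic carbon of the five-membered aromatic ring with 3 nitrogen.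

Within the data shown here, three measured steps bear on this: a step that the two limits leave unreadable from compound 2 to compound 3, a step that the two limits leave unreadable from compound 1 to compound 3 and a step that the two limits leave unreadable from compound 1 to compound 2. None of them gives a size, so no measured size can be carried over to the new change. Among the measured compounds shown here, compound 1 is the only measured compound with a sulfonyl group, and a step that the two limits leave unreadable from compound 1 to compound 3 shows no readable difference from compound 3. No gain in this assay is therefore expected from this change.

The estimated step is a number no higher from compound 3 to compound 4 (the limit leaves the size open), with none expected beyond the scatter. For compound 4 the estimate is 200 mg/kg, with an expected range from 70 mg/kg to 400 mg/kg, and a further limit is the likeliest report.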

Compound 4, dose for half-maximal effect: > 200 mg/kg
Compound 4 was reported as a limit (the forecaster's own chance of this, stated with the estimate: 70%); the middle value sits exactly at the limit.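

Compound 4 stands at > 200 mg/kg, which is a limit. Its steps from compound 1, compound 2 and compound 3 in this assay cannot be read. The compounds shown leave open whether any change to the shared core gives a number in this assay rather than a limit.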